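Formyl in Place of Ethyl on Compound 3

The compounds below may be only part of what the source reports. "The series", "measured", "known", "first", "only" and "open" are said of these compounds alone.

Three compounds share one core. Compound 1 `COc1ccccc1-c1cn2ccnc2c(-c2ccc3ncn(C4CCCCC4)c3c2)n1` gives 11.1% in a functional assay on HT-29 cells (Homo sapiens) for inhibition, read by sulforhodamine B assay, with a stated time of 48 h, tested at 10 uM (a lower number here means less inhibition, a higher number more inhibition at the concentration tested (going by the name of the read-out)), and compound 2 `FC(F)(F)c1cccc(-c2cn3ccnc3c(-c3ccc4ncn(C5CCCCC5)c4c3)n2)c1` gives 6.41%; the step of a number 4.7 percentage points lower from compound 1 to compound 2 (within the scatter) swaps the whole aromatic group on the core. Compound 3 `CCc1ccc(-c2cn3ccnc3c(-c3ccc4ncn(Cc5ccccc5)c4c3)n2)cc1` gives 68.8%, the highest of the three, beyond the scatter above both compound 1 and compound 2. Compound 4 `O=Cc1ccc(-c2cn3ccnc3c(-c3ccc4ncn(Cc5ccccc5)c4c3)n2)cc1` has not been measured; it differs from compound 3 by formyl in place of ethyl on an aromatic carbon. Among the measured compounds shown here, the only measured step, from compound 1 to compound 2, changes that same aromatic group wholesale yet stays within the scatter, so it gives weak guidance. The step of a number 23.8 percentage points lower from compound 3 to compound 4 (beyond the scatter) is therefore expected to be downward but uncertain. Compound 4 is estimated at 45%, ranging from 15% to 75%.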

Compound 4, a percentage reported as inhibition, at one concentration (the size of the read-out at that concentration, not a potency): 17.5%
Compound 4: the middle estimate sits 27.5 percentage points above what was measured; low and high end bracket the measured number.
By their numbers in this assay, from the lowest: compounds 2, 1 and 4 (each within the scatter of the next, the first and the last beyond it); then compound 3.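

On this aromatic carbon, para to a large group, exchanging ethyl for formyl gives a step of a number 51.3 percentage points lower from compound 3 to compound 4 (beyond the scatter), so the outcome at this position depends strongly on the group it carries. The earlier step of a number 4.7 percentage points lower from compound 1 to compound 2 (within the scatter), which swapped the whole aromatic group, showed no such sensitivity. No measurement at hand accounts for this drop.

From the compounds shown here alone, whether the loss is specific to formyl remains open. A hydroxymethyl, a carboxylic acid or an amine on this carbon, or a propyl chain in place of ethyl, would show how far the effect extends.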